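From Methoxy to Bromo on the Shared Core

This account rests on a few compounds, and the source may have more. Where it says the series, first, only, none or still open, it means among the compounds named here.

In a functional assay on A549 cells (Homo sapiens) for antiproliferative activity, read by MTT assay (on this read-out lower numbers stand for stronger inhibition and higher numbers for weaker inhibition), compound 1 `FC(F)(F)Sc1ccc(-c2cc(CN(c3ncccn3)c3nc4ccccc4s3)on2)cc1` gives 29800 nM, compound 2 `FC(F)(F)Oc1ccc(-c2cc(CN(c3ncccn3)c3nc4ccccc4s3)on2)cc1` gives 31800 nM, and compound 3 `COc1ccc(-c2cc(CN(c3ncccn3)c3nc4ccccc4s3)on2)cc1` gives 30500 nM. The three numbers lie on top of each other: the step of a 1.1-fold higher number from compound 1 to compound 2 (0.03 log units; within the scatter), the step of a 1.0-fold higher number from compound 1 to compound 3 (0.01 log units; within the scatter) and the step of a 1.0-fold lower number from compound 2 to compound 3 (0.02 log units; within the scatter) are all within the scatter, so compound 3 cannot be set apart from either companion on this read-out.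

Compound 4 `Brc1ccc(-c2cc(CN(c3ncccn3)c3nc4ccccc4s3)on2)cc1` differs from compound 3 in one place: bromo in place of methoxy on an aromatic carbon. Every step seen so far on this aromatic carbon, whether (trifluoromethyl)sulfanyl, trifluoromethoxy or methoxy occupied it, left this assay unmoved, and the exchange for bromo is of the same kind. He therefore expects no step beyond the scatter for compound 4, with a 1.0-fold lower number from compound 3 to compound 4 (0.01 log units; within the scatter) as the estimated change. His estimate for compound 4 in this assay is 30000 nM, expected to fall between 12000 nM and 75000 nM.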

Compound 4, half-maximal inhibitory concentration: 31500 nM
Compound 4: the middle estimate sits 1.1-fold (0.02 log units) below what was measured, within the range that was stated.
By their numbers in this assay, from the lowest: compounds 1, 3, 4 and 2 (each within the scatter of the next).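

Bromo extends the same picture to a group of a different kind: in this assay the exchange for methoxy reads as (a 1.0-fold higher number from compound 3 to compound 4 (0.01 log units; within the scatter)), and the steps from the other two groups read as (a 1.0-fold lower number from compound 2 to compound 4 (0.00 log units; within the scatter)) and (a 1.1-fold higher number from compound 1 to compound 4 (0.02 log units; within the scatter)). The position, on an aromatic carbon para to a large group, has now taken a single bromine atom as well as groups joined through oxygen or sulfur, and compounds 1, 2, 3 and 4 cannot be told apart on this read-out. Nothing available explains why these groups cannot be told apart.

From the compounds shown here alone, whether an amine, a carboxylic acid or a longer chain on this carbon would move the number remains open. All four compounds also keep the rest of the shared core unchanged, so they cannot show how that part bears on the activity.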